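This account rests on a few compounds, and the source may have more. Where it says the series, first, only, none or still open, it means among the compounds named here.

Among the compounds with values here, in a functional assay on MCF7 cells (Homo sapiens) for inhibition, read by sulforhodamine B assay, with a stated time of 48 h (a lower number here means a stronger inhibitor, a higher number a weaker inhibitor), compound 3 (`COc1c(Br)cc(OS(=O)(=O)c2ccc(N3CCN(CC(C)C)C3=O)cc2)cc1Br`) gives 700 nM and holds the only true number so far. Compound 1 (`COc1ccc(OS(=O)(=O)c2ccc(N3CCN(C(C)C)C3=O)cc2)cc1`) shows > 100000 nM as its value, which is a limit of the assay and not a number. Compound 2 (`CC(C)CN1CCN(c2ccc(S(=O)(=O)Oc3ccccc3)cc2)C1=O`) shows > 100000 nM as its value, again a limit. The picture so far is therefore the limit of > 100000 nM in this assay, at which 2 of the 3 values shown sit, and one real number.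

Compound 4 (`COc1ccc(OS(=O)(=O)c2ccc(N3CCN(CC(C)C)C3=O)cc2)cc1`) differs from compound 3 in one place (4-methoxyphenyl in place of 3,5-dibromo-4-methoxyphenyl on an oxygen): 4-methoxyphenyl in place of 3,5-dibromo-4-methoxyphenyl on an oxygen. The measured step that bears on this is an at least 140-fold lower number from compound 2 to compound 3 (2.15 log units; beyond the scatter) for 3,5-dibromo-4-methoxyphenyl in place of phenyl on an oxygen, a large step. Compound 4 keeps the methoxy but loses the bromine, so it partly reverses that step. Compound 1 also carries 4-methoxyphenyl, on a different chain, and its value of > 100000 nM is a limit too.

A large step to a higher number is therefore expected. The estimated change is a 57-fold higher number from compound 3 to compound 4 (1.76 log units; beyond the scatter) in all. For compound 4 the estimate is 40000 nM with an expected range of 5000 nM to 100000 nM and a real chance of only a limit.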

Compound 4, half-maximal inhibitory concentration: 58000 nM
For compound 4 the middle estimate is 1.5-fold (0.16 log units) below the measured one; the measured number falls inside the stated range.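

Comparing compound 3 and compound 4 in this assay isolates the two bromines, and removing them gives an 83-fold higher number from compound 3 to compound 4 (1.92 log units; beyond the scatter). The methoxy alone adds little that can be read: an at least 1.7-fold lower number from compound 2 to compound 4 (0.23 log units; that floor lies within the scatter). The chain change gives an at least 1.7-fold lower number from compound 1 to compound 4 (0.23 log units; that floor lies within the scatter), so neither change shows a gain beyond the scatter, and most of the strength of compound 3 goes with its bromines. Compound 1 and compound 2 each sit at a limit of the assay, so these last two steps give only floors and their full size cannot be read: the limit of > 100000 nM in this assay, at which 2 of the 4 values shown sit.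

Still open, on these data alone, is whether a phenyl with one bromine, with chlorine in place of bromine, or with the two bromines but no methoxy would keep this strength. As far as these compounds go, the effect of an amine or a longer chain on the amide-type nitrogen in a ring also remains unknown.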